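Pyrazolylmethyl ureas: aryl swap on the pyrazole nitrogen

The source may report more compounds than this note shows. Statements on the series, on what has been measured and on what is new or still open speak of the compounds shown alone.

Measured compounds in an assay on CHO-K1 cells for antagonist activity at transient receptor potential cation channel subfamily V member 1 (Homo sapiens), read by FLIPR and calcium flux, with a stated time of 6 min; on this read-out lower numbers stand for stronger inhibition and higher numbers for weaker inhibition:
compound 1 `CC(=O)n1ncc2c(NC(=O)NCc3cc(C(F)(F)F)nn3-c3cccc(Cl)c3)cccc21` gives 17.4 nM
compound 2 `O=C(NCc1cc(C(F)(F)F)nn1-c1cccc(C(F)(F)F)c1)Nc1cccc2[nH]ncc12` gives 1.3 nM
compound 3 `Cn1ncc2c(NC(=O)NCc3cc(C(F)(F)F)nn3-c3cccc(C(F)(F)F)c3)cccc21` gives 1.4 nM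

Compound 3 stands second highest of the three numbers in this assay ; its nearest neighbour is compound 2 and its furthest is compound 1. Among the measured compounds shown here, the only single-point step recorded, a 1.1-fold higher number from compound 2 to compound 3 (0.03 log units; within the scatter), concerns methyl in place of hydrogen on an aromatic nitrogen and lies within the scatter, so the methylated and unmethylated cores are interchangeable on these numbers.

Compound 4 `Cn1ncc2c(NC(=O)NCc3cc(C(F)(F)F)nn3-c3ccc(F)cc3)cccc21` differs from compound 3 by 4-fluorophenyl in place of 3-(trifluoromethyl)phenyl on an aromatic nitrogen. For the measured compounds named here, no measured step bears on this change. Compound 1 carries a different aryl group and also an acetyl in place of methyl, so its value cannot be split into the two changes; all that can be said is that compound 1 gives 17.4 nM, a higher number than compound 3. Going by the values given here, with no direct precedent, a moderate loss is estimated for the step of a 7.1-fold higher number from compound 3 to compound 4 (0.85 log units; beyond the scatter). Compound 4 is therefore expected to give about 10 nM, with a range from 2.5 nM to 50 nM.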

Compound 4, inhibition constant: 8.4 nM
Estimate against measurement, compound 4: 1.2-fold (0.08 log units) above; the measured number falls inside the stated range.
By their numbers in this assay, from the lowest: compounds 2 and 3 (each within the scatter of the next); then compound 4; then compound 1.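

In this assay, the aryl group on the aromatic nitrogen now has a single-change reading: a 6.0-fold higher number from compound 3 to compound 4 (0.78 log units; beyond the scatter). The earlier step, a 1.1-fold higher number from compound 2 to compound 3 (0.03 log units; within the scatter), lies within the scatter, whereas this one lies beyond it, so the number responds to the aryl swap, though only modestly, with compound 4 still at 8.4 nM. Nothing at hand accounts for the size of this step.

The swap changes the substituent and its place on the ring in one step, so these two contributions stay unseparated, and the value of compound 1 still cannot be split between its aryl group and its acetyl. As far as these compounds go, whether an unsubstituted phenyl or a cyclohexyl group on this nitrogen would hold the number remains open.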